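The source may hold more compounds than are shown below. What is called first, only, known or untested is meant among the compounds shown, and "the series" means these compounds.

Compound 1 `CC(=O)SC[C@H](NC(=O)NC[C@H](N)C(=O)O)C(=O)NCC(=O)O`: 0.74 h
Compound 2 `CCOC(=O)SC[C@H](NC(=O)NC[C@H](N)C(=O)O)C(=O)NCC(=O)O`: 2.72 h

These two compounds were measured in an ADME assay on brain (Mus musculus, strain CD-1) for metabolic stability, read by LC-MS, with a stated time of 240 min, tested at 1 uM; on this read-out higher numbers stand for a longer-lived compound and lower numbers for a shorter-lived compound. Compound 2 holds the higher of the two numbers, at 2.72 h, while compound 1 gives 0.74 h.

The next structure is compound 3 `C=C(N[C@@H](CNC(=O)N[C@@H](CSC(=O)OCC)C(=O)NCC(=O)O)C(=O)O)OCC`. It keeps everything in compound 2 except for one change: 1-ethoxyethenyl in place of hydrogen on an amine nitrogen. In words, 1-ethoxyethenyl stands in place of hydrogen on an amine nitrogen.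

For the measured compounds named here, only one measured step is available as a guide: a 3.7-fold higher number from compound 1 to compound 2 (0.57 log units; beyond the scatter). That modest step, beyond the scatter, came from ethoxy in place of methyl on a carbonyl carbon. The new change sits on an amine nitrogen instead, so this step bears on it only loosely. Going by the values given here, no measured compound carries a substituent on that nitrogen, so the data give neither a size nor a firm direction for this change. The expected result is therefore little movement, with a wide margin on both sides: a 1.1-fold higher number from compound 2 to compound 3 (0.04 log units; within the scatter), which is not expected to stand clear of the scatter.

For compound 3 the estimated half-life is 3 h, with an expected range from 1.2 h to 7 h.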

Compound 3, half-life: 9.79 h
Beside the measured number, compound 3's estimate is 3.3-fold (0.51 log units) below it, outside the stated range (above it).
By their numbers in this assay, from the lowest: compound 1; then compound 2; then compound 3.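

In this assay the amine nitrogen turns out to be a place that responds to change: 1-ethoxyethenyl in place of hydrogen there gives a 3.6-fold higher number from compound 2 to compound 3 (0.56 log units; beyond the scatter) and so moves the read-out clearly, which could not be seen while every earlier compound kept that hydrogen. The earlier change, ethoxy in place of methyl on a carbonyl carbon, gave a 3.7-fold higher number from compound 1 to compound 2 (0.57 log units; beyond the scatter) and so the two single changes shown, made at two different places, both point toward a longer-lived compound. Nothing among the data explains what lies behind the rise at the nitrogen.

For the compounds shown here, one substituent at this nitrogen gives only one step, so it remains open whether the rise needs the whole 1-ethoxyethenyl group, with its double bond and its oxygen, or would also appear with a plain ethyl group, an acetyl group or a longer chain on the same nitrogen. Going by these compounds, it is also open whether the same substituent would give a step of similar size on compound 1, which carries the methyl on the carbonyl carbon rather than the ethoxy.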